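A few compounds are considered here, and "the series" means these few. Any claim that something is new, unique, unknown or untested is made for them only; others in the source may bear on it.

Measured compounds:
compound 1 `CCN1CCCC(n2cc(S(=O)(=O)c3ccccc3)c3ccccc32)C1`, in a functional assay on HeLa cells for agonist activity at 5-hydroxytryptamine receptor 6 (Homo sapiens), read by cAMP accumulation and immunoassay, with a stated time of 10 min (on this read-out higher numbers stand for larger maximal responses and lower numbers for smaller maximal responses), compound 1 gives 52%
compound 2 `O=S(=O)(c1ccccc1)c1cn(C2CCNCC2)c2ccccc12`, in this assay compound 2 gives "not determined" (no result reported)
compound 3 `CCN1CCCC(n2cc(S(=O)(=O)c3cccc(F)c3)c3cc(OC)ccc32)C1`, in this assay compound 3 gives 50%

Compound 3 stands lowest of the two numbers that exist, but its nearest neighbour, compound 1, lies only a little higher, and that gap is within the usual scatter of this kind of measurement, so the two compounds cannot be told apart on maximal response. Compound 2 adds nothing to the comparison, since no number was reported for it.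

The next step leads from compound 3 to compound 4 `COc1ccc2c(c1)c(S(=O)(=O)c1cccc(F)c1)cn2C1CCCNC1`. The change is hydrogen in place of ethyl on an amine nitrogen in a ring, that is, 1-ethylpiperidin-3-yl to piperidin-3-yl. For the measured compounds named here, no measured pair shows this change, so no step of known size can be quoted; the only guidance is that the two existing numbers sit close together. The expectation is therefore a step in this assay that is small, most likely within the scatter, with a slight lean toward a lower maximal response. Compound 4 is expected to give about 45%, with a range from 20% to 75%. This corresponds to an estimated step of a number 5 percentage points lower from compound 3 to compound 4 (within the scatter).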

Compound 4, largest response reached (Emax), in percent of the reference or control that the assay uses: 75%
Compound 4: middle estimate off by 30 percentage points, on the low side, and the stated range covers the measured number.
By their numbers in this assay, from the lowest: compounds 3 and 1 (each within the scatter of the next); then compound 4.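

In this assay, for the compounds shown here, hydrogen in place of ethyl on the amine nitrogen in the ring gives a number 25 percentage points higher from compound 3 to compound 4 (beyond the scatter) and, with it, the first step here that lies clear of the scatter. Going by these compounds alone, no two compounds measured before this pair differed in one place only, so this is the first sign that the group on this nitrogen bears on the maximal response, and the ethyl group proves not to be needed for that response, since the piperidin-3-yl compound keeps it and reaches a larger one. Nothing measured here bears on why the response moves with this change.

The compounds shown leave open how the response would follow a methyl group or a longer chain such as propyl on the same nitrogen, since only ethyl and hydrogen can be read at this place. Within the data shown here, they also leave open whether the same change would give a step of similar size on the core of compound 1, as this single pair is the only reading of it and claims no general rule.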